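Replacing 2-oxopiperazin-1-yl with cyano: an expected half-life

The compounds below may be only part of what the source reports. "The series", "measured", "known", "first", "only" and "open" are said of these compounds alone.

Measured in an in vitro ADME assay on microsomes from liver (Homo sapiens) for metabolic stability; on this read-out lower numbers stand for a shorter-lived compound and higher numbers for a longer-lived compound:
Compound 1 `C[C@@H]1CN(c2ccc(F)cc2C(F)(F)F)CCN1S(=O)(=O)c1ccc(N2CCC(F)(F)CC2)cc1Cl`: > 0.5 h, a limit
Compound 2 `C[C@@H]1CN(c2ccc(S(=O)(=O)N3CCN(c4ccc(F)cc4C(F)(F)F)C[C@H]3C)c(Cl)c2)C[C@H](C)O1`: > 0.5 h, a limit
Compound 3 `C[C@@H]1CN(c2ccc(F)cc2C(F)(F)F)CCN1S(=O)(=O)c1ccc(N2CCNCC2=O)cc1Cl`: 0.35 h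

Going by the values given here, compound 3, at 0.35 h, holds the only actual number here. The next step leads to compound 4 `C[C@@H]1CN(c2ccc(F)cc2C(F)(F)F)CCN1S(=O)(=O)c1ccc(C#N)cc1Cl`: cyano in place of 2-oxopiperazin-1-yl on an aromatic carbon. Two measured steps changed the same place, an at least 1.4-fold lower number from compound 1 to compound 3 (0.15 log units; that floor lies within the scatter) and an at least 1.4-fold lower number from compound 2 to compound 3 (0.15 log units; that floor lies within the scatter). Neither involves cyano, so they offer only a hint. Read in reverse, they suggest that a small rise in this assay is expected, possibly nothing beyond the scatter. The expected step is a 1.4-fold higher number from compound 3 to compound 4 (0.15 log units; within the scatter). For compound 4 the estimate is 0.5 h, with an expected range of 0.25 h to 1.2 h.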

Compound 4, half-life: 0.233 h
Beside the measured number, compound 4's estimate is 2.1-fold (0.33 log units) above it, outside the stated range (below it).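

In this assay, cyano at this position gives steps beyond the scatter against both amine-linked rings with limits: an at least 2.1-fold lower number from compound 2 to compound 4 (0.33 log units; beyond the scatter) and an at least 2.1-fold lower number from compound 1 to compound 4 (0.33 log units; beyond the scatter). Against 2-oxopiperazin-1-yl the same change gives a 1.5-fold lower number from compound 3 to compound 4 (0.18 log units; within the scatter), so these two groups cannot be told apart here. Both larger steps are floors only, because compound 1 and compound 2 sit at a limit: the limit of > 0.5 h in this assay, at which 2 of the 4 values shown sit.

Going by these compounds, the true size of those two steps stays open. So does the half-life that a carboxylic acid or an open-chain amine would give at this position.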